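The compounds below may be only part of what the source reports. "The series", "measured", "known", "first", "only" and "open" are said of these compounds alone.

Two compounds share one core and differ only in the group attached to the five-membered aromatic ring that carries three nitrogens. Compound 1 `COc1ccc(OC)c(Sc2ccc3nnc(-c4cccnc4)n3n2)c1` gives 242 nM in an assay on isolated protein for inhibition of Leucine-rich repeat serine/threonine-protein kinase 2 (Homo sapiens), in the presence of a further agent that is not named here; a higher number here means a weaker inhibitor, a lower number a stronger inhibitor. Compound 2 `COc1cncc(-c2nnc3ccc(Sc4cc(OC)ccc4OC)nn23)c1` gives 66 nM in this assay, the lowest of the two numbers, and the step of a 3.7-fold lower number from compound 1 to compound 2 (0.56 log units; beyond the scatter) shows that the methoxy on the pyridine ring of compound 2 was worth a modest gain beyond the scatter.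

Compound 3 `COc1ccc(OC)c(Sc2ccc3nnc(C4CCN(C)C4)n3n2)c1` is not yet measured. It differs from compound 2 by 1-methylpyrrolidin-3-yl in place of 5-methoxypyridin-3-yl on an aromatic carbon. Among the measured compounds shown here, no measured step covers an exchange of one ring for another at this place; the single measured step only concerns a methoxy on the ring that now leaves. Because compound 1, which lacks that methoxy, gave 242 nM, removing the ring that carried it is expected to cost at least as much, so a weaker inhibitor is expected, with the step of a 7.6-fold higher number from compound 2 to compound 3 (0.88 log units; beyond the scatter) as a rough guess. For compound 3 the expected value in this assay is 500 nM, within a range of 120 nM to 2500 nM.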

Compound 3, half-maximal inhibitory concentration: 12600 nM
Beside the measured number, compound 3's estimate is 25-fold (1.40 log units) below it, outside the stated range (above it).
By their numbers in this assay, from the lowest: compound 2; then compound 1; then compound 3.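

Earlier, this position was seen only through a methoxy added to a pyridine ring that stayed in place, whereas here the whole ring is exchanged, and in this assay the loss is far larger than that earlier gain: a 190-fold higher number from compound 2 to compound 3 (2.28 log units; beyond the scatter). The same exchange starting from the pyridine ring without methoxy gives a 52-fold higher number from compound 1 to compound 3 (1.72 log units; beyond the scatter), so the large loss appears with or without that methoxy, and at this position the six-membered aromatic rings of the two earlier compounds are not interchangeable with the five-membered non-aromatic ring of 1-methylpyrrolidin-3-yl. No measurement shown here explains why this exchange costs so much.

The exchange alters several things at once: the ring size, the loss of aromaticity and the methyl-bearing ring nitrogen, and these compounds cannot separate them. On these data alone, how a phenyl ring, a piperidine ring or a pyrrolidine ring without its methyl group would compare at this place remains open.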